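Adding Trifluoromethyl to a Compound at the Assay Limit

The source may report more compounds than this note shows. Statements on the series, on what has been measured and on what is new or still open speak of the compounds shown alone.

Compound 2 `O=C(O)CCCSCCN1C(=O)OC[C@@H]1/C=C/[C@@H](O)Cc1ccccc1` was tested in an assay on CHO cells for displacement of a labelled ligand from prostaglandin E2 receptor EP1 subtype (Mus musculus), read by scintillation counting, with a stated time of 20 min; on this read-out higher numbers stand for weaker inhibition and lower numbers for stronger inhibition. In this assay compound 2 gives > 10000 nM, which is a limit of the assay rather than a number. Compound 4 `O=C(O)CCCSCCN1C(=O)OC[C@@H]1/C=C/[C@@H](O)Cc1cccc(C(F)(F)F)c1` differs from compound 2 in one place: trifluoromethyl in place of hydrogen on an aromatic carbon. The same change has been made once before among the measured compounds, in the pair of compound 1 `CCCc1cccc(C[C@H](O)/C=C/[C@H]2CSC(=O)N2CCSCCCC(=O)O)c1` and compound 3 `O=C(O)CCCSCCN1C(=O)SC[C@@H]1/C=C/[C@@H](O)Cc1cccc(C(F)(F)F)c1`, which share a core that is not the core of compound 2 and compound 4. In this assay compound 1 gives > 10000 nM, a limit of the assay. In this assay compound 3 gives > 10000 nM, also a limit of the assay. The step that the two limits leave unreadable from compound 1 to compound 3 therefore cannot be read, because of the limit of > 10000 nM in this assay, at which 3 of the 3 values shown sit. The step expected from this change is a step that the limit leaves unreadable from compound 2 to compound 4, with nothing beyond the scatter readable from what has been measured. Compound 4 is estimated at 15000 nM, within a range from 5000 nM to 50000 nM, and most probably it will again be reported only as a limit.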

Compound 4, inhibition constant: > 10000 nM
Compound 4 ended at the assay's limit (the forecaster's own chance of this, stated with the estimate: 85%); the middle value does not contradict the limit.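

No step can be read from compound 2 to compound 4, because both compounds sit at a limit of the assay and not at a number: the limit of > 10000 nM in this assay, at which 4 of the 4 values shown sit.

The compounds shown leave open whether trifluoromethyl in place of hydrogen changes inhibition at all, and what true value lies behind the limit for each compound.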